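Swapping tert-butyl for cyclopropyl on a weakly active core

A few compounds are considered here, and "the series" means these few. Any claim that something is new, unique, unknown or untested is made for them only; others in the source may bear on it.

Compound 1, `CC(C)(C)c1cn(C[C@H](O)[C@H]2OC(=O)C(OCc3ccccc3)=C2OCc2ccccc2)nn1`, gives 54900 nM in a functional assay on CFPAC-1 cells (Homo sapiens) for antiproliferative activity, read by MTT assay, with a stated time of 72 h; on this read-out lower numbers stand for stronger inhibition and higher numbers for weaker inhibition.
Compound 2, `Cc1ccc(-c2cn(C/C=C3\OC(=O)C(OCc4ccccc4)=C3OCc3ccccc3)nn2)cc1`, reaches only the limit > 100000 nM in this assay.
Compound 3, `O=C1O/C(=C\Cn2cc(-c3ccc(Br)cc3)nn2)C(OCc2ccccc2)=C1OCc1ccccc1`, reaches only the limit > 100000 nM in this assay.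

Compound 1 is therefore the only one of the three with a measured number; the other two values are limits of the assay and not numbers. Among the measured compounds shown here, the single pair that differs in one place, a step that the two limits leave unreadable from compound 2 to compound 3, cannot be read in size because of the limit of > 100000 nM in this assay, at which 2 of the 3 values shown sit. Nothing measured here touches the group on the triazole that is changed next.

Compound 4, `O=C1O[C@H]([C@@H](O)Cn2cc(C3CC3)nn2)C(OCc2ccccc2)=C1OCc1ccccc1`, differs from compound 1 by cyclopropyl in place of tert-butyl on an aromatic carbon. For the measured compounds named here, no measured step bears on this change: the only step available is unreadable and concerns a different position. With no evidence pointing either way, the expected step of a 1.1-fold higher number from compound 1 to compound 4 (0.04 log units; within the scatter) is one that stays within the usual scatter of this assay, with no clear direction. Compound 4 is therefore estimated at 60000 nM in this assay, with a range of 25000 nM to 150000 nM, and a real chance that it too is reported only as a limit.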

Compound 4, half-maximal inhibitory concentration: 47700 nM
Compound 4: the middle estimate sits 1.3-fold (0.10 log units) above what was measured, and the stated range covers the measured number.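

Swapping tert-butyl for cyclopropyl gives a 1.2-fold lower number from compound 1 to compound 4 (0.06 log units; within the scatter) in this assay, so this change makes no readable difference at this position. Tert-butyl, with 4 heavy atoms and no ring, and cyclopropyl, with 3 heavy atoms and one three-membered ring, cannot be told apart by this read-out on the shared core, which is the first direct information about this carbon of the triazole. It is also the only step among the compounds shown whose size can be read, and the other step cannot be read: the limit of > 100000 nM in this assay, at which 2 of the 4 values shown sit.

From the compounds shown here alone, two similar small carbon groups say little about how far this position tolerates change, so it remains open whether an amine, a carboxylic acid or a longer chain such as n-hexyl in the same place would move the number beyond the scatter. Compound 2 and compound 3 differ from compound 1 in more than one place, so they do not settle what a substituted phenyl ring on the triazole would do on the core of compound 1.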